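The source may report more compounds than this note shows. Statements on the series, on what has been measured and on what is new or still open speak of the compounds shown alone.

Of the compounds shown here, three that share one core have been tested in an assay on HeLa cells for inhibition of Indoleamine 2,3-dioxygenase 1 (Homo sapiens), read by spectrophotometry, with a stated time of 24 h; on this read-out lower numbers stand for an effect already at smaller amounts and higher numbers for an effect only at larger amounts of compound. Compound 1 `CN(C)S(=O)(=O)CCNc1nonc1/C(=N/O)Nc1ccc(F)c(Br)c1` carries a dimethylamino group on its sulfonyl sulfur, and in this assay compound 1 gives 17 nM. Compound 2 `O=S(=O)(CCNc1nonc1/C(=N/O)Nc1ccc(F)c(Br)c1)N1CCC1` carries an azetidin-1-yl group in that place, and compound 2 gives 143 nM; the step of an 8.4-fold higher number from compound 1 to compound 2 (0.92 log units; beyond the scatter) lies beyond the scatter. Compound 3 `NNS(=O)(=O)CCNc1nonc1/C(=N/O)Nc1ccc(F)c(Br)c1` carries an aminoamino group on the sulfonyl sulfur. For compound 3 this assay reports only a limit, > 800 nM, not a number. Compound 3 thus stands at the weak end of what has been measured: the steps of an at least 47-fold higher number from compound 1 to compound 3 (1.67 log units; beyond the scatter) and an at least 5.5-fold higher number from compound 2 to compound 3 (0.74 log units; beyond the scatter) both run upward and beyond the scatter.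

Compound 4 `O=S(=O)(CCNc1nonc1/C(=N/O)Nc1ccc(F)c(Br)c1)NO` differs from compound 3 in one place: hydroxy in place of amino on a sulfonamide nitrogen. Going by the values given here, no measured step tests a hydroxy group on that nitrogen, so the expectation rests on the neighbouring changes. The aminoamino group of compound 3 pushed the number past what the assay reads, as the limit of > 800 nM in this assay, at which 1 of the 3 values shown sits, records, and a single small group on the sulfonamide nitrogen is again present in compound 4. Compound 4 is therefore expected to remain weak, with an estimated value of 700 nM, between 150 nM and 3000 nM. The step of an at least 1.1-fold lower number from compound 3 to compound 4 (0.05 log units; that floor lies within the scatter) that this estimate implies is expected to stay within the scatter.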

Compound 4, half-maximal effective concentration: > 800 nM
Compound 4: only a limit was reported; the forecaster's own chance of this, stated with the estimate: 45%; middle value at least 1.1-fold (0.05 log units) from the limit.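

In this assay compound 4 has only a limit, > 800 nM, and not a number, so hydroxy in place of amino on the sulfonamide nitrogen does not bring back a readable value, and the second small group tested there ends at the same limit as the first: the limit of > 800 nM in this assay, at which 2 of the 4 values shown sit. The step from compound 3 to compound 4 cannot be read, as both values are limits, so the two groups cannot be ranked against each other. What can be read is how far the hydroxyamino group lies from the two groups that gave numbers, with an at least 5.5-fold higher number from compound 2 to compound 4 (0.74 log units; beyond the scatter) and with an at least 47-fold higher number from compound 1 to compound 4 (1.67 log units; beyond the scatter), and the carbon-bearing groups of compound 1 and compound 2 are so far the only ones on this sulfur to give a number.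

A methylamino group on the sulfonyl sulfur would show whether a single carbon on that nitrogen is enough to give a readable value. Going by these compounds, a diethylamino group or a pyrrolidin-1-yl group would show how larger carbon groups compare with dimethylamino, and the true values of compound 3 and compound 4 also remain unknown.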